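The compounds below may be only part of what the source reports. "The series", "measured", "known", "first", "only" and "open" are said of these compounds alone.

In an ADME assay on THP-1 cells (Homo sapiens) for cytotoxicity (on this read-out lower numbers stand for higher toxicity in this test and higher numbers for lower toxicity in this test), compound 3 (`COc1ccc(NC(=O)c2c(NC(=O)c3ccccc3)sc3c2CCCCC3)cc1`) gives > 50000 nM, which is a limit and not a number. Compound 1 (`COC(=O)Nc1sc2c(c1C(=O)Nc1ccc(OC)cc1)CCCCC2`) gives > 50000 nM, also a limit. Compound 2 (`COc1ccc(NC(=O)c2c(NC(=O)C(F)(F)F)sc(C)c2C)cc1`) gives > 50000 nM, again a limit. The whole record so far is the limit of > 50000 nM in this assay, at which 3 of the 3 values shown sit. Compound 4 (`COc1ccc(NC(=O)c2c(NC(C)=O)sc3c2CCCCC3)cc1`) turns the benzamido group of compound 3 into acetamido, putting methyl in place of phenyl on a carbonyl carbon. Among the compounds with values here, the one measured step at such a carbonyl carbon is a step that the two limits leave unreadable from compound 1 to compound 3, so it offers no size to carry over. No step beyond the usual scatter is therefore expected in this assay, in either direction. The estimated change is a number no higher from compound 3 to compound 4 (the limit leaves the size open). For compound 4 the expected value is 50000 nM, with an estimated range from 25000 nM to 100000 nM.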

Compound 4, half-maximal cytotoxic concentration: > 50000 nM
Compound 4: a limit, no number; the forecaster's own chance of this, stated with the estimate: 85%; the middle value lies on the limit itself.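

Within the data shown here, no step to compound 4 can be read from compound 1 or compound 3, since each value is a limit and not a number: the limit of > 50000 nM in this assay, at which 4 of the 4 values shown sit. How far any of these compounds lies from that limit in this assay stays open, as does whether the group on the carbonyl carbon changes the read-out at all.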